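The source may hold more compounds than are shown below. What is called first, only, known or untested is meant among the compounds shown, and "the series" means these compounds.

Values from a functional assay on HEL cells (Homo sapiens) (on this read-out lower numbers stand for higher toxicity in this test and higher numbers for lower toxicity in this test), for the measured compounds
Compound 1 `CCCCCCCC#Cc1cc2cn(COCCO)c(=O)nc2o1` gives > 50000 nM
Compound 2 `CCCCCCCCCCCc1cc2cn(COCCO)c(=O)nc2o1` gives 132000 nM

Compound 1 reads > 50000 nM, which is a limit of the assay and not a number. Among the measured compounds shown here, compound 2 at 132000 nM holds the only actual number so far. Compound 3 `CCCCCCc1cc2cn(COCCO)c(=O)nc2o1` differs from it by hydrogen in place of pentyl on a saturated chain carbon, six bonds along the chain from an aromatic carbon with hydrogen in place of pentyl on a saturated chain carbon. For the measured compounds named here, no measured pair shows this change. Compound 2 at 132000 nM already stands at a high number, so a small move toward lower toxicity, or none beyond the scatter, is expected in this assay for this change. The expected change a 1.1-fold higher number from compound 2 to compound 3 (0.06 log units; within the scatter) is therefore modest. For compound 3 the estimated value is 150000 nM with 50000 nM to 400000 nM as the expected range.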

Compound 3, half-maximal cytotoxic concentration: > 200000 nM
Compound 3 ended at the assay's limit; the forecaster's own chance of this, stated with the estimate: 45%; middle value at least 1.3-fold (0.12 log units) away from the limit.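

In this assay, among the compounds shown here, hydrogen in place of pentyl on this saturated chain carbon gives an at least 1.5-fold higher number from compound 2 to compound 3 (0.18 log units; that floor lies within the scatter) as the first step that can be read at this position. That step is only a floor, and it does not clear the usual scatter, because compound 3 stands at a limit of the assay and not at a number: the limit of > 200000 nM in this assay, at which 1 of the 3 values shown sits. From the compounds shown here alone, the true size of this change therefore stays unknown. Also open, going by these compounds, is how a chain ending in an amine or a carboxylic acid at this place would read in this assay.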